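A Single Aryl Swap on an Arylpiperazine Amide

The source may hold more compounds than are shown below. What is called first, only, known or untested is meant among the compounds shown, and "the series" means these compounds.

Measured compounds:
compound 1 `CC1(c2ccccc2)CC(=O)N(CC(=O)N2CCN(c3ccc(Cl)cc3)CC2)C1=O` — 300 mg/kg
compound 2 `CC1(c2ccccc2)CC(=O)N(CC(=O)N2CCN(c3ccc(Cl)c(Cl)c3)CC2)C1=O` — reported as not active, without a number

Going by the values given here, in a functional assay on the whole organism (strain CD-1) with Mus musculus as the target, with a stated time of 2 h (a higher number here means that more compound is needed for the effect, a lower number that less compound is needed), compound 1 gives 300 mg/kg, the only number in this set. Compound 2 is recorded only as not active, so no number stands beside compound 1 for comparison. Compound 3 `CC1(c2ccccc2)CC(=O)N(CC(=O)N2CCN(c3cccc(C(F)(F)F)c3)CC2)C1=O` is not yet measured. Against compound 1 it shows (3-(trifluoromethyl)phenyl in place of 4-chlorophenyl on an amine nitrogen in a ring). Among the compounds with values here, no step between measured compounds is available to size this change. Since compound 2 also carries a group on this ring and in this assay gives "not active" (no number reported), the expectation for compound 3 is a weak result, with a real chance that only "not active" is reported. The estimated step of a 1.3-fold higher number from compound 1 to compound 3 (0.12 log units; within the scatter) is expected to be small but in the direction of needing more compound. Compound 3 is estimated at 400 mg/kg, within a range from 150 mg/kg to 1000 mg/kg.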

Compound 3, minimum effective dose: "not active" (no number reported)
Nothing numeric was reported for compound 3, so the estimate cannot be set against anything.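

Going by these compounds alone, compound 3, like compound 2, is recorded in this assay only as not active, so no step from compound 1 to compound 3 can be read. No measured evidence bears on this result. The compounds shown leave open whether any aryl group other than 4-chlorophenyl gives a number in this assay.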